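A few compounds are considered here, and "the series" means these few. Any claim that something is new, unique, unknown or untested is made for them only; others in the source may bear on it.

Working notes on the series. Of the compounds shown here, two sharing one core have been measured in an assay for displacement of a labelled ligand from Sigma non-opioid intracellular receptor 1 (Cavia porcellus), read by scintillation counting, with a stated time of 180 min; a higher number here means a weaker inhibitor, a lower number a stronger inhibitor. Compound 1 `CCCN1CCC2(CC1)OC(OC)Cc1c2cnn1-c1ccccc1` carries a propyl on the ring amine nitrogen; in this assay compound 1 gives 33 nM. Compound 2 `CCCCN1CCC2(CC1)OC(OC)Cc1c2cnn1-c1ccccc1` carries a butyl in its place; in this assay compound 2 gives 8 nM. Going by the values given here, the single measured step, a 4.1-fold lower number from compound 1 to compound 2 (0.62 log units; beyond the scatter), consists of methyl in place of hydrogen on a saturated chain carbon, three bonds along the chain from an amine nitrogen in a ring. Compound 2 therefore holds the lower of the two numbers, and its gap to compound 1 lies beyond the scatter.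

Compound 3 `CCCCCN1CCC2(CC1)OC(OC)Cc1c2cnn1-c1ccccc1` is not yet measured. Its difference from compound 2 is methyl in place of hydrogen on a saturated chain carbon, four bonds along the chain from an amine nitrogen in a ring; read one bond further out, the same change is butyl to pentyl. Among the compounds with values here, the only step that bears on it is a 4.1-fold lower number from compound 1 to compound 2 (0.62 log units; beyond the scatter), the same kind of chain lengthening one bond nearer the nitrogen. Nothing in the measured data says whether a second such lengthening continues that trend or levels off. The expectation is therefore a smaller step in the same direction, a 1.6-fold lower number from compound 2 to compound 3 (0.20 log units; within the scatter), with a range wide enough to include no change beyond the scatter. For compound 3 the estimated value is 5 nM, between 2 nM and 15 nM.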

Compound 3, inhibition constant: 0.82 nM
Compound 3: middle estimate off by 6.1-fold (0.79 log units), on the high side; measured number outside the range, below it.
By their numbers in this assay, from the lowest: compound 3; then compound 2; then compound 1.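

The change of methyl in place of hydrogen, four bonds along the chain from an amine nitrogen in a ring, shows no levelling off at butyl: in this assay it gives a 9.8-fold lower number from compound 2 to compound 3 (0.99 log units; beyond the scatter), a step no smaller than the earlier 4.1-fold lower number from compound 1 to compound 2 (0.62 log units; beyond the scatter). Across propyl, butyl and pentyl on the ring amine nitrogen, the number falls with each lengthening, none of these three compounds goes against that order, and the two lengthenings together amount to a 40-fold lower number from compound 1 to compound 3 (1.60 log units; beyond the scatter). Nothing at hand explains this result.

These three chains leave open whether the fall continues, stops or reverses with a longer chain such as hexyl or heptyl. They also leave open how a branched chain such as isopentyl, or a chain ending in a phenyl ring, would read on the same nitrogen, and whether the pentyl gain holds when the methoxy group on the shared core is replaced by another group, such as ethoxy.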